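Amide-side variation in the series: from compound 1 to compound 4

The source may hold more compounds than are shown below. What is called first, only, known or untested is meant among the compounds shown, and "the series" means these compounds.

Measured in a functional assay on B16 cells (Mus musculus) for inhibition (a higher number here means a weaker inhibitor, a lower number a stronger inhibitor), so far:
- compound 1 `O=C(/C=C/c1ccc(O)c(O)c1)NC1CCCC1` gives 30000 nM
- compound 2 `O=C(/C=C/c1ccc(O)c(O)c1)NC1CCCCC1` gives 2800 nM
- compound 3 `COc1ccc(CNC(=O)/C=C/c2ccc(O)c(O)c2)cc1` gives 6200 nM

Compound 1 carries the highest of the three numbers, and both other compounds lie beyond the scatter from it. The next step leads to compound 4 `O=C(/C=C/c1ccc(O)c(O)c1)N1CCNCC1`, not yet measured, with piperazin-1-yl in place of cyclopentylamino on a carbonyl carbon. The counted difference is piperazin-1-yl in place of cyclopentylamino on a carbonyl carbon at that place.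

For the measured compounds named here, only one measured step bears on this site: an 11-fold lower number from compound 1 to compound 2 (1.03 log units; beyond the scatter) for cyclohexyl in place of cyclopentyl on an amide-type nitrogen. That step is large, so the number in this assay can move strongly with this substituent. Going by the values given here, no measured compound carries piperazin-1-yl, so the data do not fix the direction. Compound 2 at 2800 nM and compound 3 at 6200 nM both sit lower than compound 1, which tilts the expectation towards a lower number.

The expected step is a 2.0-fold lower number from compound 1 to compound 4 (0.30 log units; within the scatter) in this assay with wide uncertainty. The estimate for compound 4 is 15000 nM within an expected range from 3000 nM to 60000 nM for now.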

Compound 4, half-maximal inhibitory concentration: > 40000 nM
Compound 4: only a limit was reported; the forecaster's own chance of this, stated with the estimate: 20%; middle value at least 2.6-fold (0.42 log units) from the limit.
By their numbers in this assay, from the lowest: compound 2; then compound 3; then compound 1. At a limit, above all of these: compound 4.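

Compound 4 stands at a limit of this assay, not at a number: the limit of > 40000 nM in this assay, at which 1 of the 4 values shown sits.

The step is an at least 1.3-fold higher number from compound 1 to compound 4 (0.12 log units; that floor lies within the scatter), so this floor alone does not separate the two compounds. Even so, the earlier step at this place, an 11-fold lower number from compound 1 to compound 2 (1.03 log units; beyond the scatter), pointed only towards a lower number, and piperazin-1-yl in place of cyclopentylamino on a carbonyl carbon shows that a change here need not bring any such gain.

Going by these compounds, how far the true value of compound 4 lies past the limit remains open. Also open, on these data alone, is whether the second ring nitrogen of piperazin-1-yl matters, a question that a piperidin-1-yl or morpholin-4-yl group on the same carbonyl carbon would address.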